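Swapping a ring on the thienopyrimidine side chain

The source may report more compounds than this note shows. Statements on the series, on what has been measured and on what is new or still open speak of the compounds shown alone.

Compound 1 `Nc1nc(-c2ccco2)nc2sc(CN3CCC(F)CC3)cc12`: 740 nM
Compound 2 `Nc1nc(-c2ccco2)nc2sc(CN3CC=CC3)cc12`: 290 nM
Compound 3 `Nc1nc(-c2cccc(C(F)(F)F)c2)nc2sc(CN3CC=CC3)cc12`: 2960 nM

In an assay on CHO-K1 cells for antagonist activity at adenosine receptor A1 (Homo sapiens), read by a beta-galactosidase reporter, with stated times of 15 min and 6 h (a lower number here means a stronger inhibitor, a higher number a weaker inhibitor), compound 2 gives 290 nM, and compound 1 gives 740 nM. The step of a 2.6-fold higher number from compound 2 to compound 1 (0.41 log units; beyond the scatter) comes from the change (a group of 7 heavy atoms (5 carbon, 1 nitrogen, 1 fluorine; one six-membered non-aromatic ring with 1 hetero atom) in place of a group of 5 heavy atoms (4 carbon, 1 nitrogen; one five-membered non-aromatic ring with 1 hetero atom), on a saturated chain carbon bound to an aromatic carbon). Compound 3, which gives 2960 nM, shares this side chain with compound 2 but carries a different core; the difference between the two cores is not broken down here. Compound 4 `Nc1nc(-c2cccc(C(F)(F)F)c2)nc2sc(CN3CCC(F)CC3)cc12` is related to compound 3 by the change (a group of 7 heavy atoms (5 carbon, 1 nitrogen, 1 fluorine; one six-membered non-aromatic ring with 1 hetero atom) in place of a group of 5 heavy atoms (4 carbon, 1 nitrogen; one five-membered non-aromatic ring with 1 hetero atom), on a saturated chain carbon bound to an aromatic carbon), the same change at the same place as from compound 2 to compound 1. If the step repeats on the core of compound 3, the expected step is a 2.6-fold higher number from compound 3 to compound 4 (0.42 log units; beyond the scatter), resting on the measured step of a 2.6-fold higher number from compound 2 to compound 1 (0.41 log units; beyond the scatter). Compound 4 is therefore estimated at 7700 nM, likely between 3500 nM and 17000 nM.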

Compound 4, inhibition constant: 3030 nM
Beside the measured number, compound 4's estimate is 2.5-fold (0.41 log units) above it, and the stated range ends above it.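

On the core of compound 3, putting 4-fluoropiperidin-1-yl in place of the five-membered ring gives a 1.0-fold higher number from compound 3 to compound 4 (0.01 log units; within the scatter), so on this core the swap leaves no readable difference in this assay. Set beside the earlier step, this one does not differ from it by more than the scatter: the same change on two cores in this assay, a 2.6-fold higher number (0.41 log units; beyond the scatter) from compound 2 to compound 1 and a 1.0-fold higher number (0.01 log units; within the scatter) from compound 3 to compound 4, 2.5-fold (0.40 log units) apart, within the scatter of two such steps. Going by these compounds alone, this shows no firm sign that the core alters the effect of the change, but it does not show that the effect carries over either, as only two pairs bear on it and one step is within the scatter.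

From the compounds shown here alone, it remains open how the change behaves on further cores. Going by these compounds, it is also open what an open-chain diethylamino group or a carboxylic acid would do on the same saturated chain carbon.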